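Trading a dimethylamino tail for a plain butyl chain

The source may hold more compounds than are shown below. What is called first, only, known or untested is meant among the compounds shown, and "the series" means these compounds.

Two compounds give the footing for this account. Compound 1 `CN(C)CCCn1c(=O)n(C2OC(CO)[C@@H](O)[C@H]2O)c2nc(N)nc(O)c21` carries a 3-(dimethylamino)propyl chain on one ring nitrogen and a sugar on the other; compound 2 `C=CCn1c(=O)n(CCCC)c2nc(N)nc(O)c21` carries an allyl group and a butyl chain instead. In a functional assay on the whole organism (B cells) with Mus musculus as the target (on this read-out higher numbers stand for larger maximal responses and lower numbers for smaller maximal responses), compound 1 gives 83%, and in this assay compound 2 gives 77%. The two numbers sit within the usual scatter of each other, so neither compound can be set ahead of the other on this read-out; compound 1 simply provides the closest starting point for the question that follows.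

That question concerns compound 3 `CCCCn1c(=O)n(C2OC(CO)[C@@H](O)[C@H]2O)c2nc(N)nc(O)c21`, which keeps the sugar of compound 1 and differs from it in one place: methyl in place of dimethylamino on a saturated chain carbon, three bonds along the chain from an aromatic nitrogen. Among the compounds with values here, no pair of measured compounds separated by a single change is available, so the size of this step cannot be read from data. The expectation is a step of a number 5 percentage points lower from compound 1 to compound 3 (within the scatter), small and not beyond the scatter. Compound 3 is therefore estimated to give 78%, within a range from 60% to 95%.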

Compound 3, largest response reached (reported as maximal response), in percent of the reference or control that the assay uses: 86%
Beside the measured number, compound 3's estimate is 8 percentage points below it; low and high end bracket the measured number.
By their numbers in this assay, from the lowest: compounds 2, 1 and 3 (each within the scatter of the next).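

In this assay the change from 3-(dimethylamino)propyl to butyl is a step of a number 3 percentage points higher from compound 1 to compound 3 (within the scatter), so with the sugar kept in place, this position takes the plain chain without a step that can be told from the scatter. Within the data shown here, compound 1 and compound 2 differ in more than one place and could give no such reading; this single change is the first to be read, and it shows that a maximal response of this size does not depend on the dimethylamino group on this chain of the core. Nothing measured here accounts for the two chains reading alike.

The compounds shown leave open whether a shorter chain such as propyl, a longer chain such as hexyl, or a chain ending in a primary amine or a carboxylic acid would hold the response at this position. Also open, from the compounds shown here alone, is whether the sugar itself is needed while the butyl chain stays, for instance with a plain methyl group on that ring nitrogen instead.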